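Series notes: methyl added on the aromatic-ring nitrogen

A few compounds are considered here, and "the series" means these few. Any claim that something is new, unique, unknown or untested is made for them only; others in the source may bear on it.

Measured so far:
compound 1 `CNc1nc(NCc2ccc(C(=O)NC3CCN(Cc4ccc(F)cc4)CC3)cc2)c2cc(C)ccc2n1` — 1200 nM
compound 2 `CCNc1nc(NCc2ccc(NC(=O)c3ccc(F)cc3)cc2Cl)c2ccccc2n1` — 1500 nM

In a functional assay on HCT-116 cells (Homo sapiens) for inhibition, read by luminescence and resazurin assay, with a stated time of 3 days (a lower number here means a stronger inhibitor, a higher number a weaker inhibitor), compound 1 gives 1200 nM, and compound 2 gives 1500 nM; the two values lie within the scatter of each other, so neither separates from the other. Compound 3 `Cc1ccc2nc(N(C)C)nc(NCc3ccc(C(=O)NC4CCN(Cc5ccc(F)cc5)CC4)cc3)c2c1` differs from compound 1 by methyl in place of hydrogen on a nitrogen on an aromatic ring, that is, methylamino to dimethylamino. Going by the values given here, no step between measured compounds covers this change, so only an expectation can be given: a small step in this assay, if any, more likely toward a higher number than a lower one. Compound 3 is estimated at 2000 nM, range 700 nM to 6000 nM, the expected step from compound 1 being a 1.7-fold higher number from compound 1 to compound 3 (0.22 log units; within the scatter).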

Compound 3, half-maximal inhibitory concentration: 800 nM
Compound 3: middle estimate off by 2.5-fold (0.40 log units), on the high side, within the range that was stated.
By their numbers in this assay, from the lowest: compounds 3, 1 and 2 (each within the scatter of the next).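

In this assay, methylamino to dimethylamino gives a 1.5-fold lower number from compound 1 to compound 3 (0.18 log units; within the scatter), so this pair shows no separable effect of the added methyl. The hydrogen on this nitrogen is therefore not needed to keep the value of compound 1 in this assay. No measurement on hand accounts for the result.

Still open, on these data alone, is whether this nitrogen also accepts a propyl chain or a cyclic amine such as morpholine. Also open, as far as these compounds go, is whether the same methyl change reads alike on the rest of compound 2.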